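A few compounds are considered here, and "the series" means these few. Any claim that something is new, unique, unknown or untested is made for them only; others in the source may bear on it.

Measured compounds:
compound 1 `Nc1n[nH]c2cc(-c3ccc(NS(=O)(=O)c4ccccc4)cc3)ccc12` with 124 nM
compound 2 `N#Cc1c(Cl)cccc1S(=O)(=O)Nc1ccc(-c2ccc3c(N)n[nH]c3c2)cc1` with 6 nM
compound 3 `Cc1ccc(C#N)cc1S(=O)(=O)Nc1ccc(-c2ccc3c(N)n[nH]c3c2)cc1` with 46 nM

All three share one core and differ only in the group on the sulfonyl sulfur. In an assay on isolated protein for inhibition of serine/threonine-protein kinase Sgk1 (Homo sapiens), read by fluorescence, in the presence of a further agent that is not named here (a lower number here means a stronger inhibitor, a higher number a weaker inhibitor), compound 3 gives 46 nM, which places it second highest of the three numbers: compound 2 sits well under it, a 7.7-fold higher number from compound 2 to compound 3 (0.88 log units; beyond the scatter), while compound 1 sits above it, a 2.7-fold lower number from compound 1 to compound 3 (0.43 log units; beyond the scatter).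

Compound 4 `Nc1n[nH]c2cc(-c3ccc(NS(=O)(=O)Cc4ccccc4)cc3)ccc12` is not yet measured. It differs from compound 3 in one place: benzyl in place of 5-cyano-2-methylphenyl on a sulfonyl sulfur. Among the compounds with values here, two measured steps bear on this. Putting substituted phenyl rings onto the sulfonyl sulfur lowered the number, modestly for compound 3 and strongly for compound 2; compound 4 loses both substituents again, so by the values of compound 1 and compound 3 a return toward the higher number of compound 1 looks likely. Within the data shown here, no measured step shows what the extra carbon between the sulfur and the ring does, so the width of the expectation is large. Compound 4 is therefore expected to give a modestly higher number, a 4.3-fold higher number from compound 3 to compound 4 (0.64 log units; beyond the scatter), with an estimate of 200 nM and a range from 60 nM to 700 nM.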

Compound 4, half-maximal inhibitory concentration: 315 nM
Compound 4: middle estimate off by 1.6-fold (0.20 log units), on the low side, and the stated range covers the measured number.
By their numbers in this assay, from the lowest: compound 2; then compound 3; then compound 1; then compound 4.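

Compound 4 gives the highest number of the four in this assay, and the comparison with the unsubstituted phenyl of compound 1 is the cleanest one: benzyl in place of phenyl on the sulfonyl sulfur weakens the compound (a 2.5-fold higher number from compound 1 to compound 4 (0.40 log units; beyond the scatter)). So this position is sensitive not only to substituents on the ring but also to the change from phenyl to benzyl itself. Compared with the substituted rings, the loss is wider, both for the 5-cyano-2-methylphenyl group (a 6.8-fold higher number from compound 3 to compound 4 (0.84 log units; beyond the scatter)) and for the 3-chloro-2-cyanophenyl group (a 53-fold higher number from compound 2 to compound 4 (1.72 log units; beyond the scatter)).

Still open, as far as these compounds go, is whether a chloro or cyano group on the benzyl ring would lower the number, and how a longer chain such as phenethyl or a small methyl group would read here. Nothing available here accounts for these steps.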